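Adding a methyl to the ring amine of compound 3

The source may report more compounds than this note shows. Statements on the series, on what has been measured and on what is new or still open speak of the compounds shown alone.

Measured in a physicochemical assay for lipophilicity, measured as octanol-water partition, at pH 7.4; a higher number here means a more lipophilic compound, a lower number a more polar compound:
- compound 1 `O=C(N[C@H]1CN(S(=O)(=O)c2ccccc2)C[C@@H]1C(=O)N[C@H]1CCCNC1)c1cn(C2CC2)cn1` gives -0.7
- compound 2 `O=C(N[C@H]1CN(S(=O)(=O)c2ccccc2)C[C@@H]1C(=O)N[C@H]1CCCNC1)c1nnc(-c2ccc(F)cc2)s1` gives 1
- compound 3 `O=C(N[C@H]1CN(S(=O)(=O)c2ccccc2)C[C@@H]1C(=O)N[C@H]1CCCNC1)c1cc(-c2ccccc2Cl)on1` gives 1.9

Compound 3 stands highest of the three, with a number 2.60 log units higher from compound 1 to compound 3 (beyond the scatter) and a number 0.90 log units higher from compound 2 to compound 3 (beyond the scatter) as its steps from the others. Compound 4 `CN1CCC[C@H](NC(=O)[C@H]2CN(S(=O)(=O)c3ccccc3)C[C@@H]2NC(=O)c2cc(-c3ccccc3Cl)on2)C1` has methyl in place of hydrogen on an amine nitrogen in a ring, the difference being methyl in place of hydrogen on an amine nitrogen in a ring in full.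

Going by the values given here, none of the measured steps touches that place. All of them, a number 1.70 log units higher from compound 1 to compound 2 (beyond the scatter) included, exchange the whole group on a carbonyl carbon, large or modest in size, and so give no direct measure for a single methyl. Only a small upward step is expected in this assay, perhaps no more than the scatter. The expected move is a number 0.30 log units higher from compound 3 to compound 4 (within the scatter) on this reading. Compound 4 is estimated at 2.2 with an expected range from 1.7 to 2.7 for the measurement.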

Compound 4, distribution coefficient: 3.1
Estimate against measurement, compound 4: 0.90 log units below; measured number outside the range, above it.
By their numbers in this assay, from the lowest: compound 1; then compound 2; then compound 3; then compound 4.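

In this assay, going from piperidin-3-yl to 1-methylpiperidin-3-yl gives a number 1.20 log units higher from compound 3 to compound 4 (beyond the scatter), so the amine nitrogen in the ring is a place where a single methyl produces a large step. Earlier movement came only from exchanging the whole group on a carbonyl carbon, and this one-carbon change is comparable in size to a number 0.90 log units higher from compound 2 to compound 3 (beyond the scatter), a swap of entire groups of that kind. Nothing measured here accounts for the size of the step.

As far as these compounds go, the methyl has been read only with the carbonyl group of compound 3, and whether it moves the number similarly with the groups of compound 1 or compound 2 stays open. Also open, from the compounds shown here alone, is how an ethyl, a longer chain or an acetyl on the same nitrogen would stand against hydrogen and methyl in this assay.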